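Methoxy to bromo on the sulfonyl aryl ring

The source may report more compounds than this note shows. Statements on the series, on what has been measured and on what is new or still open speak of the compounds shown alone.

Compound 1 `CCCc1nc2c(C)cc(-c3nc4ccccc4n3C)cc2n1S(=O)(=O)c1ccccc1` carries an unsubstituted phenylsulfonyl group on the shared core. In a functional assay on HCT-116 cells (Homo sapiens) for cytotoxicity, read by MTT assay (a lower number here means a stronger inhibitor, a higher number a weaker inhibitor), compound 1 reaches only a limit of the assay, > 50000 nM. Compound 2 `CCCc1nc2c(C)cc(-c3nc4ccccc4n3C)cc2n1S(=O)(=O)c1ccc(C)cc1` adds a methyl to that ring and gives 41600 nM in this assay. Compound 3 `CCCc1nc2c(C)cc(-c3nc4ccccc4n3C)cc2n1S(=O)(=O)c1ccc(OC)cc1` bears a methoxy instead and gives 19100 nM in this assay, the lowest of the two numbers shown; its nearest neighbour is compound 2, separated by a 2.2-fold lower number from compound 2 to compound 3 (0.34 log units; beyond the scatter). Of the steps from the parent, an at least 1.2-fold lower number from compound 1 to compound 2 (0.07 log units; that floor lies within the scatter) stays within the scatter, whereas an at least 2.6-fold lower number from compound 1 to compound 3 (0.41 log units; beyond the scatter) goes beyond it; both are floors because of the limit of > 50000 nM in this assay, at which 1 of the 3 values shown sits. Compound 4 `CCCc1nc2c(C)cc(-c3nc4ccccc4n3C)cc2n1S(=O)(=O)c1ccc(Br)cc1` differs from compound 3 by bromo in place of methoxy on an aromatic carbon. Among the compounds with values here, no measured step exchanges methoxy for bromo; the three measured steps only show that a group on the aromatic carbon para to the large group moves the number by modest amounts, and the methoxy was the most favourable of them. A return toward compound 2 is therefore expected, and the step estimated for compound 4 is a 1.5-fold higher number from compound 3 to compound 4 (0.17 log units; within the scatter). Compound 4 is expected to give 28000 nM in this assay, with a range from 9000 nM to 60000 nM.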

Compound 4, half-maximal inhibitory concentration: 49300 nM
Compound 4: the middle estimate sits 1.8-fold (0.25 log units) below what was measured, within the range that was stated.
By their numbers in this assay, from the lowest: compound 3; then compounds 2 and 4 (each within the scatter of the next). At a limit, above all of these: compound 1.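

In this assay, bromo in place of methoxy on the aromatic carbon para to a large group gives a 2.6-fold higher number from compound 3 to compound 4 (0.41 log units; beyond the scatter), so the lower number seen with the methoxy is not shared by the bromo. Bromo in place of methyl on that carbon gives a 1.2-fold higher number from compound 2 to compound 4 (0.07 log units; within the scatter), so those two groups cannot be told apart here. Compound 3, with the methoxy, stands apart from both compound 2 and compound 4. Against the unsubstituted ring, the bromo gives an at least 1.0-fold lower number from compound 1 to compound 4 (0.00 log units; that floor lies within the scatter), which is only a floor and cannot be read as a change, because compound 1 stands only at a limit of the assay: the limit of > 50000 nM in this assay, at which 1 of the 4 values shown sits.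

As far as these compounds go, what remains open is whether another group on this carbon, such as an amine, a hydroxyl or a carboxylic acid, would lower the number further than the methoxy. Also open, from the compounds shown here alone, is whether a longer chain on that oxygen, such as an ethoxy, would keep the methoxy's standing.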